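The compounds below may be only part of what the source reports. "The series", "measured", "known", "first", "only" and "open" are said of these compounds alone.

Working notes on a short series of acetylated unsaturated pyranose sulfonamides. Compound 1 `CC(=O)OC[C@H]1O[C@H](NS(=O)(=O)c2ccc(C)cc2)C(OC(C)=O)=C[C@@H]1OC(C)=O` gives 39200000 nM in a functional assay on HepG2 cells (Homo sapiens) for cytotoxicity, read by MTT assay, with a stated time of 48 h; on this read-out lower numbers stand for stronger inhibition and higher numbers for weaker inhibition. Compound 2 `CC(=O)OC[C@H]1O[C@H](NS(=O)(=O)c2ccc(C)cc2)C=C[C@@H]1OC(C)=O` gives 157000000 nM, the step being a 4.0-fold higher number from compound 1 to compound 2 (0.60 log units; beyond the scatter). Compound 3 `CCS(=O)(=O)N[C@@H]1C=C[C@H](OC(C)=O)[C@@H](COC(C)=O)O1` gives 231000000 nM, the step being a 1.5-fold higher number from compound 2 to compound 3 (0.17 log units; within the scatter). Compound 3 therefore holds the highest number of the three, with compound 2 within the scatter of it and compound 1 beyond it.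

Compound 4 `CCS(=O)(=O)N[C@H]1O[C@H](COC(C)=O)[C@@H](OC(C)=O)C=C1OC(C)=O` differs from compound 3 by acetoxy in place of hydrogen on a double-bonded ring carbon. Within the data shown here, the only measured step that bears on this is the one from compound 1 to compound 2, the same change run in reverse, which was modest and beyond the scatter. A lower number of about that size is therefore expected for compound 4 in this assay. Compound 4 is expected to give 58000000 nM, with a range of 25000000 nM to 140000000 nM, an estimated step of a 4.0-fold lower number from compound 3 to compound 4 (0.60 log units; beyond the scatter).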

Compound 4, half-maximal inhibitory concentration: 14700000 nM
Beside the measured number, compound 4's estimate is 3.9-fold (0.60 log units) above it; measured number outside the range, below it.
By their numbers in this assay, from the lowest: compound 4; then compound 1; then compounds 2 and 3 (each within the scatter of the next).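

Acetoxy in place of hydrogen on the double-bonded ring carbon gives a 16-fold lower number from compound 3 to compound 4 (1.20 log units; beyond the scatter) in this assay, so the size of this change differs with the group on the sulfonyl sulfur: the same change on two cores in this assay, a 4.0-fold higher number (0.60 log units; beyond the scatter) from compound 1 to compound 2 and a 16-fold higher number (1.20 log units; beyond the scatter) from compound 4 to compound 3, 3.9-fold (0.59 log units) apart, beyond the scatter of two such steps

Ethyl in place of 4-methylphenyl, within the scatter on the core without acetoxy, gives a 2.7-fold lower number from compound 1 to compound 4 (0.43 log units; beyond the scatter) on the core that carries it: the same change on two cores in this assay, a 1.5-fold higher number (0.17 log units; within the scatter) from compound 2 to compound 3 and a 2.7-fold lower number (0.43 log units; beyond the scatter) from compound 1 to compound 4, 3.9-fold (0.59 log units) apart, beyond the scatter of two such steps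

Across these four compounds, the two places therefore do not add independently.

Open, on these data alone, is whether a hydroxyl or an amine on this ring carbon would match acetoxy, and whether a longer chain on the sulfonyl sulfur would follow ethyl or 4-methylphenyl.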